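The source may report more compounds than this note shows. Statements on the series, on what has been measured and on what is new or still open speak of the compounds shown alone.

Working notes on the shared core, following the step from compound 3 to compound 4.

Compound 1 `CC(C)Cc1ccc2c(NCCCNCc3ccco3)ccnc2c1` gives 4200 nM in a physicochemical assay for solubility, with a stated time of 18 h, at pH 7.4; a lower number here means a less soluble compound, a higher number a more soluble compound. Compound 2 `Fc1ccc(Cc2ccc3c(NCCCNCc4ccco4)ccnc3c2)c(Cl)c1` gives 4200 nM in this assay, and compound 3 `Cc1cc(C)cc(Cc2ccc3c(NCCCNCc4ccco4)ccnc3c2)c1` gives 4200 nM in this assay. Compound 3 therefore stands level with compound 1 and compound 2 at the digits shown: the steps of no change at the digits printed from compound 1 to compound 3 (within the scatter) and no change at the digits printed from compound 2 to compound 3 (within the scatter) lie within the scatter, as does no change at the digits printed from compound 1 to compound 2 (within the scatter).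

Compound 4 `COc1ccc(-c2ccc3c(NCCCNCc4ccco4)ccnc3c2)cc1` has not been measured in this assay. It differs from compound 3 as follows: 4-methoxyphenyl in place of 3,5-dimethylbenzyl on an aromatic carbon. Going by the values given here, this change is of a different kind from the measured steps, which exchanged one group for another on a saturated chain carbon bound to an aromatic carbon, whereas here the entering group sits on an aromatic carbon; no measured pair carries a 4-methoxyphenyl or the one hydrogen-bond acceptor counted for it. Every measured exchange at the varied position left this assay unchanged within the scatter, so for compound 4 the expected step is no change at the digits printed from compound 3 to compound 4 (within the scatter), nothing beyond the scatter. Compound 4 is estimated at 4200 nM, between 1400 nM and 12600 nM, in this assay; the range is set wider than the scatter, since this kind of change is unsampled.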

Compound 4, solubility: 32000 nM
Estimate against measurement, compound 4: 7.6-fold (0.88 log units) below, outside the stated range (above it).
By their numbers in this assay, from the lowest: compounds 1, 2 and 3 (each within the scatter of the next); then compound 4.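

In this assay, going by these compounds alone, replacing the benzyl-type or isobutyl group with 4-methoxyphenyl on the aromatic carbon gives a 7.6-fold higher number from compound 3 to compound 4 (0.88 log units; beyond the scatter), a 7.6-fold higher number from compound 2 to compound 4 (0.88 log units; beyond the scatter) and a 7.6-fold higher number from compound 1 to compound 4 (0.88 log units; beyond the scatter), so this position is not indifferent to every exchange, as the earlier compounds alone suggested. The three steps share one entering group, and it differs from all three leaving groups in two ways at once: its aromatic ring stands directly on the aromatic carbon, with no saturated chain carbon in the link, and it carries one hydrogen-bond acceptor where each leaving group counts none. No evidence bears on the reason for the rise, and the result rests on compound 4 alone.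

The two differences cannot be separated by the compounds shown: an unsubstituted phenyl on the same aromatic carbon and a 4-methoxybenzyl would each carry only one of them. From the compounds shown here alone, whether the higher number extends to other entering groups, such as a pyridine or a carboxylic acid on this aromatic carbon, also remains open.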